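Series notes: fluoro ortho to a methoxy group

The source may hold more compounds than are shown below. What is called first, only, known or untested is meant among the compounds shown, and "the series" means these compounds.

Measured compounds in a functional assay on CHO cells for positive allosteric modulation of metabotropic glutamate receptor 2 (Homo sapiens), read by scintillation counting and GTPgammaS binding, with a stated time of 30 min; a higher number here means a larger maximal response, a lower number a smaller maximal response:
- compound 1 `CC(C)CCn1ccc(-c2ccccc2)c(C#N)c1=O`: 117%
- compound 2 `COc1ccc(-c2ccn(CCC(C)C)c(=O)c2C#N)cc1`: 160%
- compound 3 `COc1cccc(-c2ccn(CCC(C)C)c(=O)c2C#N)c1`: 176%

Compound 2 stands second highest of the three maximal responses: compound 3 is higher, by a margin beyond the scatter, and compound 1 is lower, again beyond the scatter. The two measured steps both add a methoxy group to the core of compound 1: a number 43 percentage points higher from compound 1 to compound 2 (beyond the scatter) and a number 59 percentage points higher from compound 1 to compound 3 (beyond the scatter), each a large rise in maximal response.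

Compound 4 `COc1ccc(-c2ccn(CCC(C)C)c(=O)c2C#N)cc1F` differs from compound 2 as follows: fluoro in place of hydrogen on an aromatic carbon. Among the measured compounds shown here, no measured step adds a fluoro group, so the methoxy steps do not directly bear on this change; they only show that the maximal response can move a long way with a single substituent. For the measured compounds named here, with no fluoro precedent, the expectation for compound 4 is a step within the scatter, no change at the digits printed from compound 2 to compound 4 (within the scatter), and a wide range around it. Compound 4 is therefore estimated at 160%, between 125% and 195%.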

Compound 4, largest response reached (Emax), in percent of the reference or control that the assay uses: 160%
Beside the measured number, compound 4's estimate shows no gap at the digits printed; measured number inside the range.
By their numbers in this assay, from the lowest: compound 1; then compounds 2 and 4 (each within the scatter of the next); then compound 3.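

In this assay fluoro in place of hydrogen on an aromatic carbon, ortho to a methoxy group and meta to a large group, gives no change at the digits printed from compound 2 to compound 4 (within the scatter) and so shows that this position accepts fluoro with the maximal response held. The earlier steps shown here covered only methoxy in place of hydrogen, as in a number 43 percentage points higher from compound 1 to compound 2 (beyond the scatter) and a number 59 percentage points higher from compound 1 to compound 3 (beyond the scatter) for the two large rises, and neither put a second substituent on a ring already bearing methoxy. Nothing available explains why the fluoro step leaves the response as it is.

As far as these compounds go, whether fluoro has the same outcome on the methoxy-bearing ring of compound 3 stays open. Also open, from the compounds shown here alone, is how this position responds to a group other than fluoro, such as chloro, trifluoromethyl or an amine.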